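The compounds below may be only part of what the source reports. "The series", "measured", "known", "first", "only" and "open" are said of these compounds alone.

Compound 3 `OCCCNc1nc(-c2ccccc2)nc2c1nnn2Cc1ccccc1` is a hydroxypropylamino analogue whose benzyl group carries no substituent. In an assay on Cerebral cortex for displacement of a labelled ligand from adenosine receptor A1 (Bos taurus) (a higher number here means a weaker inhibitor, a lower number a stronger inhibitor), compound 3 gives 21.4 nM. Among the three measured compounds this places compound 3 second highest; its nearest neighbour is compound 2 `CCCCCCNc1nc(-c2ccccc2)nc2c1nnn2Cc1ccccc1F`, which in this assay gives 25 nM, a gap that lies within the scatter, while compound 1 `CCCCNc1nc(-c2ccccc2)nc2c1nnn2Cc1ccccc1F` sits furthest away and gives 4.3 nM, a gap beyond the scatter.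

Compound 4 `OCCCNc1nc(-c2ccccc2)nc2c1nnn2Cc1ccccc1F` differs from compound 3 by fluoro in place of hydrogen on an aromatic carbon. Within the data shown here, the only measured step, a 5.8-fold higher number from compound 1 to compound 2 (0.76 log units; beyond the scatter), concerns ethyl in place of hydrogen on the saturated chain and so does not bear on a fluorine entering the aromatic ring. Compounds 1 and 2 both carry the fluorine, but each also differs from compound 3 in the side chain, so the data hold no clean comparison of fluorine against hydrogen at this aromatic carbon. Without a bearing step, no change beyond the scatter is expected; the step of a 1.4-fold lower number from compound 3 to compound 4 (0.15 log units; within the scatter) is therefore estimated as small. Compound 4 is expected to give about 15 nM, with a range from 6 nM to 40 nM.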

Compound 4, inhibition constant: 3.7 nM
Estimate against measurement, compound 4: 4.1-fold (0.61 log units) above; measured number outside the range, below it.
By their numbers in this assay, from the lowest: compounds 4 and 1 (each within the scatter of the next); then compounds 3 and 2 (each within the scatter of the next).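

In this assay, among these compounds, the step of a 5.8-fold lower number from compound 3 to compound 4 (0.76 log units; beyond the scatter) gives the first clean reading of fluoro in place of hydrogen on this aromatic carbon, ortho to a large group: going from benzyl to 2-fluorobenzyl with the side chain unchanged yields a stronger inhibitor, by a margin beyond the scatter. With the 2-fluorobenzyl group held constant, the side chain can now be read as well: the step of a 1.2-fold lower number from compound 1 to compound 4 (0.07 log units; within the scatter) lies within the scatter, so the chains of these two compounds are not told apart here, whereas the step of a 6.8-fold lower number from compound 2 to compound 4 (0.83 log units; beyond the scatter) lies beyond it, in favour of the hydroxy-bearing chain. Nothing given here accounts for the size of the fluoro step.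

The compounds shown leave open whether fluoro in place of hydrogen would give a step of similar size on the chains of compound 1 or compound 2. They also leave open whether chloro or methoxy on the same aromatic carbon would match fluoro, and whether an amine in place of the hydroxy group at the chain end would keep the number of compound 4.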